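Chloro for Dimethylamino: What Compound 3 Should Show

A few compounds are considered here, and "the series" means these few. Any claim that something is new, unique, unknown or untested is made for them only; others in the source may bear on it.

Compound 1, `CC1=CC[C@@H]([C@@](C)(O)CCCC(C)(C)NC(=S)N/N=C\c2ccc(C)cc2)CC1`: 30500 nM
Compound 2, `CC1=CC[C@@H]([C@@](C)(O)CCCC(C)(C)NC(=S)N/N=C\c2ccc(N(C)C)cc2)CC1`: > 100000 nM, a limit of the assay rather than a number

Both compounds share one core and differ only in the group carried on the aromatic ring. In a functional assay on NCI/ADR cells (Homo sapiens) for cytotoxicity, read by sulforhodamine B assay (on this read-out higher numbers stand for weaker inhibition of growth and lower numbers for stronger inhibition of growth), compound 1 gives 30500 nM. For compound 2 the assay reports only a limit, > 100000 nM, so compound 2 stands at the weak end of the numbers shown. Going by these compounds, the step of an at least 3.2-fold higher number from compound 1 to compound 2 (0.51 log units; beyond the scatter) weakened growth inhibition beyond the scatter, and its full size stays open because of the limit of > 100000 nM in this assay, at which 1 of the 2 values shown sits.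

Compound 3, `CC1=CC[C@@H]([C@@](C)(O)CCCC(C)(C)NC(=S)N/N=C\c2ccc(Cl)cc2)CC1`, has not yet been measured. It differs from compound 2 by chloro in place of dimethylamino on an aromatic carbon. Among the measured compounds shown here, the only measured step that bears on this change is the one from compound 1 to compound 2, which introduced the dimethylamino group and weakened inhibition. Removing that group again, now in favour of chloro, is expected to move the number back toward the region of compound 1, as an expected step of an at least 2.5-fold lower number from compound 2 to compound 3 (0.39 log units; beyond the scatter). For compound 3 the estimated value is 40000 nM, expected to fall between 15000 nM and 100000 nM.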

Compound 3, concentration for total growth inhibition: 36400 nM
The estimate for compound 3 lay 1.1-fold (0.04 log units) above the measured number; low and high end bracket the measured number.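

In this assay, chloro in place of dimethylamino gives an at least 2.7-fold lower number from compound 2 to compound 3 (0.43 log units; beyond the scatter), so the weak standing of compound 2 does not belong to the shared core alone and changes with the group on this aromatic carbon. The second comparison gives a 1.2-fold higher number from compound 1 to compound 3 (0.08 log units; within the scatter), so this read-out does not separate chloro from methyl at this place, and two different groups now give values within the scatter of each other. Of the three compounds, only the one carrying dimethylamino stands apart, and the full size of its gap from the other two stays open because compound 2 is reported only as a limit: the limit of > 100000 nM in this assay, at which 1 of the 3 values shown sits.

The compounds shown leave open whether that gap belongs to dimethylamino in particular or would also appear with a primary amine, a morpholine or a carboxylic acid on the same aromatic carbon. They also leave open whether methoxy, bromo or a longer chain such as propyl at this place would stay level with methyl and chloro or move the number in either direction.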